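The source may report more compounds than this note shows. Statements on the series, on what has been measured and on what is new or still open speak of the compounds shown alone.

Measured in an in vitro ADME assay on microsomes from liver (Homo sapiens) for metabolic stability, read by LC-MS, tested at 1 uM; on this read-out lower numbers stand for slow clearance and higher numbers for fast clearance:

Compound 1 `COCCN(C)S(=O)(=O)c1ccc(C)c(C#Cc2cc(Cl)ccc2OCC(=O)O)c1`: 32 mL.min-1.g-1
Compound 2 `Cc1ccc(S(=O)(=O)N(C)C(C)C)cc1C#Cc1cc(Cl)ccc1OCC(=O)O`: < 10 mL.min-1.g-1 (a limit)
Compound 3 `Cc1ccc(S(=O)(=O)N2CCOCC2)cc1C#Cc1cc(Cl)ccc1OCC(=O)O`: < 10 mL.min-1.g-1 (a limit)

Compound 3 sits at the limit of < 10 mL.min-1.g-1 in this assay, at which 2 of the 3 values shown sit, which is a limit and not a number. The same limit is all that is known of compound 2.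

The next compound, compound 4 `Cc1ccc(S(=O)(=O)N2CCCCC2C)cc1C#Cc1cc(Cl)ccc1OCC(=O)O`, carries 2-methylpiperidin-1-yl in place of morpholin-4-yl on a sulfonyl sulfur. The difference counts as follows: 2-methylpiperidin-1-yl in place of morpholin-4-yl on a sulfonyl sulfur.

Among the compounds with values here, no measured step makes this exact exchange, but three steps concern the same place. The first is an at least 3.2-fold lower number from compound 1 to compound 2 (0.50 log units; beyond the scatter), and the second is an at least 3.2-fold lower number from compound 1 to compound 3 (0.50 log units; beyond the scatter). Both lie beyond the scatter, and both are bounds rather than exact sizes. The third, a step that the two limits leave unreadable from compound 2 to compound 3, gives no readable size. Compound 1 at 32 mL.min-1.g-1 shows that a change on the sulfonyl sulfur alone can give a measurable clearance in this assay. A modest rise is therefore expected, although a result that stays at the limit would not be surprising. The expected step is an at least 1.8-fold higher number from compound 3 to compound 4 (0.25 log units; that floor lies within the scatter). The estimate for compound 4 is 18 mL.min-1.g-1, within an expected range from 7 mL.min-1.g-1 to 50 mL.min-1.g-1.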

Compound 4, intrinsic clearance in microsomes: 89 mL.min-1.g-1
Estimate against measurement, compound 4: 4.9-fold (0.69 log units) below; measured number outside the range, above it.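

In this assay, this position on the sulfonyl sulfur proves able to carry clearance well clear of the assay limit: 2-methylpiperidin-1-yl in place of morpholin-4-yl gives an at least 8.9-fold higher number from compound 3 to compound 4 (0.94 log units; beyond the scatter), and in place of isopropyl(methyl)amino it gives an at least 8.9-fold higher number from compound 2 to compound 4 (0.94 log units; beyond the scatter). Among the earlier compounds, only the open-chain (2-methoxyethyl)(methyl)amino group of compound 1 had given a measurable number, yet the step to the ring here is a 2.8-fold higher number from compound 1 to compound 4 (0.44 log units; beyond the scatter), so a six-membered non-aromatic ring on this sulfur does not by itself keep the number low, as morpholin-4-yl in compound 3 and 2-methylpiperidin-1-yl in compound 4 show side by side. The two larger steps start from limits, so they are floors and not exact sizes: the limit of < 10 mL.min-1.g-1 in this assay, at which 2 of the 4 values shown sit.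

The exchange from compound 3 to compound 4 removes the ring oxygen and adds a methyl group at once, and the compounds shown leave open which of the two carries the step; plain piperidin-1-yl would separate them. Also open, as far as these compounds go, is how the number would respond to a hydroxyl group or a carboxylic acid on that ring.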